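The source may report more compounds than this note shows. Statements on the series, on what has been measured and on what is new or still open speak of the compounds shown alone.

Series notes. Compound 1 `CCCCNc1nc(N)nc2c1CCNC2` gives 0.6 uM in an assay on HEK293 cells for agonist activity at Toll-like receptor 8 (Homo sapiens), read by a luciferase reporter, with a stated time of 6 h (on this read-out higher numbers stand for an effect only at larger amounts of compound and lower numbers for an effect already at smaller amounts), the larger of the two numbers available, though only by a gap that lies within the scatter. Compound 2 `CCCCNc1nc(N)nc2c1CN(C(C)=O)CC2` gives 0.5 uM in this assay; the two values are not distinguishable. Compound 3 `CCCCNc1nc(N)nc2c1CCN(C(C)=O)C2` differs from compound 1 in one place: acetyl in place of hydrogen on an amine nitrogen in a ring. Among the compounds with values here, no pair of measured compounds differs by this change alone, so the step has no precedent. The step expected from it, a 1.2-fold lower number from compound 1 to compound 3 (0.08 log units; within the scatter), is none beyond the scatter. Compound 3 is therefore estimated at 0.5 uM in this assay, with a range from 0.2 uM to 1.5 uM.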

Compound 3, minimum effective concentration: 0.4 uM
The estimate for compound 3 lay 1.3-fold (0.10 log units) above the measured number, within the range that was stated.
By their numbers in this assay, from the lowest: compounds 3, 2 and 1 (each within the scatter of the next).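

In this assay, acetyl in place of hydrogen on an amine nitrogen in a ring gives a 1.5-fold lower number from compound 1 to compound 3 (0.18 log units; within the scatter). This position therefore tolerates the acetyl, and in this one pair the hydrogen on that nitrogen is not needed to keep the read-out at this level. No measurement bearing on the reason for this is available. Still open, going by these compounds, is whether a longer acyl chain, a benzoyl or a simple methyl on the same nitrogen would hold this level. A basic amine or a carboxylic acid carried on an acyl chain there is equally untested by the compounds shown.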